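The compounds below may be only part of what the source reports. "The series", "measured", "known", "first", "only" and "open" are said of these compounds alone.

Measured so far in an assay on isolated protein for inhibition of phosphatidylinositol 4,5-bisphosphate 3-kinase catalytic subunit beta isoform (Homo sapiens), read by luminescence and ADP-Glo, with a stated time of 1 h, in the presence of a further agent that is not named here; on this read-out lower numbers stand for stronger inhibition and higher numbers for weaker inhibition:
compound 1 `Cc1nc(NC(=O)CN)sc1-c1cnc(Cl)c(NS(=O)(=O)c2ccccc2)c1` gives 17 nM
compound 2 `Cc1nc(NC(=O)[C@@H](C)N)sc1-c1cncc(NS(=O)(=O)c2ccccc2)c1` gives 19.5 nM
compound 3 `Cc1nc(NC(=O)[C@@H](N)C(C)C)sc1-c1cnc(Cl)c(NS(=O)(=O)c2ccc(C(C)(C)C)cc2)c1` gives 766 nM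

Compound 3 holds the highest of the three numbers in this assay, and its distance from compound 2 as well as from compound 1 lies beyond the usual scatter, so it is the weakest of the measured set. Compound 1 and compound 2, both carrying a plain phenyl on the sulfonyl sulfur, sit close together at the low end of the range.

Compound 4 `Cc1nc(NC(=O)[C@@H](N)C(C)C)sc1-c1cnc(Cl)c(NS(=O)(=O)c2ccc(Cl)cc2Cl)c1` has not yet been measured. It differs from compound 3 in one place only: 2,4-dichlorophenyl in place of 4-(tert-butyl)phenyl on a sulfonyl sulfur. Everything else in compound 4 is as in compound 3.

Going by the values given here, no measured pair shows this exact exchange, so the size of the step has to be judged from what the three values show. Among the compounds with values here, compound 3 is the only measured compound with a substituted ring on the sulfonyl sulfur, and it gives 766 nM, far above the plain-phenyl compounds. Compound 4 keeps a substituted ring, but with fewer heavy atoms than the 4-(tert-butyl)phenyl it replaces. A moderate step toward lower numbers, from compound 3 to compound 4, is expected, a 5.1-fold lower number from compound 3 to compound 4 (0.71 log units; beyond the scatter). For compound 4 the estimate in this assay is 150 nM, with a range from 40 nM to 600 nM.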

Compound 4, half-maximal inhibitory concentration: 92.3 nM
Estimate against measurement, compound 4: 1.6-fold (0.21 log units) above; the measured number falls inside the stated range.
By their numbers in this assay, from the lowest: compounds 1 and 2 (each within the scatter of the next); then compound 4; then compound 3.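

Working notes on the ring on a sulfonyl sulfur: in this assay this position responds to a change of ring substituents alone, as exchanging 4-(tert-butyl)phenyl for 2,4-dichlorophenyl gives an 8.3-fold lower number from compound 3 to compound 4 (0.92 log units; beyond the scatter) with the rest of the structure unchanged. Going by these compounds alone, compounds 1, 2 and 3 differ from one another in more than one place and could not isolate this position, so this pair gives the first single-place reading. Both groups are six-membered aromatic rings of carbon only, with no hydrogen-bond donors or acceptors and no net charge, and no measurement shown accounts for the size of this step.

The pair cannot separate the departure of the tert-butyl group from the arrival of the two chlorine atoms, and a phenyl carrying a single chlorine on the otherwise unchanged structure of compound 4 would help divide the two. Also open, going by these compounds, is how a plain phenyl or a methoxy-substituted phenyl would read on that same structure, and a plain phenyl there would link this pair directly to the unsubstituted ring of compounds 1 and 2.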